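Hydroxy for chloro on a second pyrimidine core

This account rests on a few compounds, and the source may have more. Where it says the series, first, only, none or still open, it means among the compounds named here.

Measured compounds:
compound 1 `N#Cc1c(-c2ccc(Cl)cc2)nc(SCC(=O)Nn2c(COc3ccc(Cl)cc3Cl)nc3ccccc3c2=O)[nH]c1=O` gives 64.9%
compound 2 `N#Cc1c(-c2ccc(O)cc2)nc(SCC(=O)Nn2c(COc3ccc(Cl)cc3Cl)nc3ccccc3c2=O)[nH]c1=O` gives 68.4%
compound 3 `N#Cc1c(Cl)nc(SCC(=O)Nn2c(COc3ccc(Cl)cc3Cl)nc3ccccc3c2=O)nc1-c1ccc(Cl)cc1` gives 68.4%

Of the compounds shown here, three have been tested in a functional assay on the whole organism (strain albino) for inhibition, with Rattus norvegicus as the target, read by paw edema, with stated times of 1 h and 3 h, at a dose of 100 mg/kg by the oral route; on this read-out lower numbers stand for a weaker effect and higher numbers for a stronger effect at the one dose given. Compound 1 `N#Cc1c(-c2ccc(Cl)cc2)nc(SCC(=O)Nn2c(COc3ccc(Cl)cc3Cl)nc3ccccc3c2=O)[nH]c1=O` gives 64.9% in this assay. Compound 2 `N#Cc1c(-c2ccc(O)cc2)nc(SCC(=O)Nn2c(COc3ccc(Cl)cc3Cl)nc3ccccc3c2=O)[nH]c1=O` differs from compound 1 by hydroxy in place of chloro on an aromatic carbon. In this assay compound 2 gives 68.4%; the step of a number 3.5 percentage points higher from compound 1 to compound 2 (within the scatter) is one that a repeated measurement could easily reproduce or reverse. Compound 3 `N#Cc1c(Cl)nc(SCC(=O)Nn2c(COc3ccc(Cl)cc3Cl)nc3ccccc3c2=O)nc1-c1ccc(Cl)cc1` has a different core, and the difference between the two cores is not broken down here; in this assay compound 3 gives 68.4%, the same number as compound 2 at the digits reported.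

Compound 4 `N#Cc1c(Cl)nc(SCC(=O)Nn2c(COc3ccc(Cl)cc3Cl)nc3ccccc3c2=O)nc1-c1ccc(O)cc1` has not yet been measured. Among the measured compounds shown here, it differs from compound 3 by hydroxy in place of chloro on an aromatic carbon, which is the same change, at the same kind of place, as the one that turns compound 1 into compound 2. For the measured compounds named here, the one earlier instance of this change moved the read-out only within the scatter, so on the core of compound 3 the expected step is likewise small: compound 4 is estimated to lie at a number 1.6 percentage points higher from compound 3 to compound 4 (within the scatter) from compound 3, because compound 3 already stands at 68.4% and the earlier change gave a number 3.5 percentage points higher from compound 1 to compound 2 (within the scatter). The estimate for compound 4 in this assay is therefore 70%, with an expected range from 60% to 79%.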

Compound 4, a percentage reported as inhibition, in the whole organism at one dose (the size of the read-out at that dose, not a potency): 73.7%
Compound 4: the middle estimate sits 3.7 percentage points below what was measured; low and high end bracket the measured number.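

In this assay, the change from 4-chlorophenyl to 4-hydroxyphenyl on the second core amounts to a number 5.3 percentage points higher from compound 3 to compound 4 (within the scatter), and the two instances of the change can now be set side by side: the same change on two cores in this assay, a number 3.5 percentage points higher (within the scatter) from compound 1 to compound 2 and a number 5.3 percentage points higher (within the scatter) from compound 3 to compound 4, 1.8 percentage points apart, within the scatter of two such steps. Read together, the two pairs show that the change carries from one core to the other without a difference that can be told apart, and that on neither core does it lower the read-out beyond the scatter. They do not show that hydroxy adds to the effect on either core, as each step on its own lies within the scatter, and two pairs read at a single dose say nothing about potency or about any core other than these two.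

The compounds shown leave open whether a different group at this place on the aromatic ring, such as an amine, a methoxy group or a carboxylic acid, would move the read-out beyond the scatter. They also leave open what would follow if the chloro on the core of compound 4 gave way to an amine or a longer chain.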